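A few compounds are considered here, and "the series" means these few. Any claim that something is new, unique, unknown or untested is made for them only; others in the source may bear on it.

Measured so far in an assay on cells for binding affinity to prostaglandin D2 receptor 2 (Homo sapiens), read by radioligand binding; on this read-out lower numbers stand for stronger inhibition and higher numbers for weaker inhibition:
- compound 1, `Cc1c(C2c3ccccc3S(=O)(=O)N2CCC(C)C)c2ccccc2n1CC(=O)O`, compound 1 gives 560 nM
- compound 2, `Cc1noc(C)c1CN1C(c2c(C)n(CC(=O)O)c3ccc(Cl)cc23)c2ccccc2S1(=O)=O`, compound 2 gives 8 nM
- compound 3, `Cc1noc(C)c1CN1C(C)(c2c(C)n(CC(=O)O)c3ccccc23)c2ccccc2S1(=O)=O`, compound 3 gives 38 nM

Compound 2 stands lowest of the three in this assay, its steps to compound 3 and to compound 1 both lying beyond the usual scatter. No pair among these three differs in one place only, so no single step is set out; compound 1 and compound 2, which differ in more than one place, merely show the widest gap of the set.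

Compound 4, `Cc1c(C2NS(=O)(=O)c3ccccc32)c2cc(Cl)ccc2n1CC(=O)O`, is not yet measured. It differs from compound 2 in one place: hydrogen in place of (3,5-dimethyl-1,2-oxazol-4-yl)methyl on a sulfonamide nitrogen in a ring. Within the data shown here, nothing in the measured set removes that nitrogen substituent outright; the only compound without the (3,5-dimethyl-1,2-oxazol-4-yl)methyl group, compound 1, carries a different group there and also lacks the chlorine, so it cannot fix the size of the step. The expectation is a loss in this assay well beyond the scatter, with wide uncertainty. For compound 4 the estimate is 400 nM, in the range 80 nM to 3000 nM, which is expected to amount to a 50-fold higher number from compound 2 to compound 4 (1.70 log units; beyond the scatter).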

Compound 4, inhibition constant: 690 nM
Beside the measured number, compound 4's estimate is 1.7-fold (0.24 log units) below it; low and high end bracket the measured number.
By their numbers in this assay, from the lowest: compound 2; then compound 3; then compounds 1 and 4 (each within the scatter of the next).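

Among these compounds, replacing (3,5-dimethyl-1,2-oxazol-4-yl)methyl with hydrogen on the sulfonamide nitrogen in a ring gives in this assay an 86-fold higher number from compound 2 to compound 4 (1.94 log units; beyond the scatter) and supplies the only single-place step so far, a large one that lies beyond the scatter. Among the compounds shown here, every earlier compound carries a group on this nitrogen, so only this step shows that, on the core of compound 2, much of the strength in this assay depends on the substituent at this position. Nothing at hand bears on why the step is so large, and it stands as an observation only.

As far as these compounds go, it remains open whether the full (3,5-dimethyl-1,2-oxazol-4-yl)methyl group is needed here or whether a simple methyl, a benzyl group or a short chain ending in an amine on the same nitrogen would restore the number seen for compound 2. It is also open whether the step keeps its size on a core without the chlorine, since no pair shown differs in that way at this nitrogen alone.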